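Shifting the chlorine on the aryl group of compound 1

A few compounds are considered here, and "the series" means these few. Any claim that something is new, unique, unknown or untested is made for them only; others in the source may bear on it.

Three hydroxamic acids were measured in an assay on Sf9 cells for inhibition of protein deacetylase HDAC6 (Homo sapiens), read by fluorescence, with a stated time of 40 min; a higher number here means a weaker inhibitor, a lower number a stronger inhibitor. Compound 1 `O=C(NO)c1ccc(NCc2nc(-c3cccc(Cl)c3)nn2-c2ccccc2)cc1` gives 115 nM, the second highest of the three numbers. Its nearest neighbour is compound 2 `COc1ccc(-n2nc(-c3ccc(O)cc3)nc2CNc2ccc(C(=O)NO)cc2)cc1`, which gives 102 nM, within the scatter of compound 1. The furthest is compound 3 `O=C(NO)c1ccc(NCc2nc(-c3ccccc3)nn2-c2ccc(F)cc2)cc1`, which gives 274 nM, a higher number than compound 1 and beyond the scatter.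

Compound 4 `O=C(NO)c1ccc(NCc2nc(-c3ccccc3Cl)nn2-c2ccccc2)cc1` has the same atoms as compound 1, joined differently: 2-chlorophenyl in place of 3-chlorophenyl on an aromatic carbon. Within the data shown here, no measured pair isolates this kind of change, so the expectation rests on compound 1 alone. The estimated step from compound 1 to compound 4 in this assay, a 1.3-fold higher number from compound 1 to compound 4 (0.12 log units; within the scatter), is expected to stay within the scatter, with wide uncertainty in either direction. Compound 4 is expected to give 150 nM, in a range from 60 nM to 400 nM.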

Compound 4, half-maximal inhibitory concentration: 185 nM
For compound 4 the middle estimate is 1.2-fold (0.09 log units) below the measured one; the range from low to high includes it.
By their numbers in this assay, from the lowest: compounds 2, 1, 4 and 3 (each within the scatter of the next, the first and the last beyond it).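

In this assay the move of the chlorine gives a 1.6-fold higher number from compound 1 to compound 4 (0.21 log units; within the scatter), the first step read at this position, on an aromatic carbon of the five-membered aromatic ring. With 2-chlorophenyl in place of 3-chlorophenyl, the two chlorine placements cannot be told apart in this assay. No measured evidence here bears on why the result falls this way.

Still open, as far as these compounds go, is whether an amine or a carboxylic acid in place of the chlorine would give a step beyond the scatter. The compounds shown also leave open whether the same move of the chlorine would read alike on the other substituted cores.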